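Adding a Methyl to the Unsubstituted Phenyl Ring

The compounds below may be only part of what the source reports. "The series", "measured", "known", "first", "only" and "open" are said of these compounds alone.

In a functional assay on the whole organism for inhibition, with Mythimna separata as the target, with a stated time of 5 days (on this read-out lower numbers stand for an effect already at smaller amounts and higher numbers for an effect only at larger amounts of compound), compound 3 `CC(C)(C)n1ncc(OCc2nnc(-c3ccccc3)o2)c(Cl)c1=O` gives 12.2 ug/mL.
Compound 2 `CC(C)(C)n1ncc(OCc2nnc(-c3c(F)cccc3F)o2)c(Cl)c1=O` gives 45.4 ug/mL.
Compound 1 `CC(C)(C)n1ncc(OCc2nnc(-c3cc(F)c(F)cc3F)o2)c(Cl)c1=O` gives 75.7 ug/mL.

Compound 3 stands lowest of the three, set apart from compound 2 by a 3.7-fold lower number from compound 2 to compound 3 (0.57 log units; beyond the scatter) and from compound 1 by a 6.2-fold lower number from compound 1 to compound 3 (0.79 log units; beyond the scatter). Compound 4 `Cc1cccc(-c2nnc(COc3cnn(C(C)(C)C)c(=O)c3Cl)o2)c1` differs from compound 3 by methyl in place of hydrogen on an aromatic carbon. Going by the values given here, no measured step adds a group to this ring; the two steps that reach compound 3 both remove fluorine atoms and lower the number, so they bear on the new change only loosely. Because compound 3 gives 12.2 ug/mL with nothing on the phenyl, adding a methyl is expected to move the number little, if anything upward, as a 1.5-fold higher number from compound 3 to compound 4 (0.17 log units; within the scatter). Compound 4 is therefore estimated at 18 ug/mL, with a range from 7 ug/mL to 45 ug/mL.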

Compound 4, half-maximal effective concentration: 116 ug/mL
Compound 4: middle estimate off by 6.4-fold (0.81 log units), on the low side, and the stated range ends below it.
By their numbers in this assay, from the lowest: compound 3; then compounds 2, 1 and 4 (each within the scatter of the next, the first and the last beyond it).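

A single methyl on the bare phenyl ring is enough to give a 9.5-fold higher number from compound 3 to compound 4 (0.98 log units; beyond the scatter) and so this place does not simply tolerate an added carbon. Against the 2,6-difluorophenyl ring, the 3-methylphenyl ring gives a 2.6-fold higher number from compound 2 to compound 4 (0.41 log units; beyond the scatter) while a 1.5-fold higher number from compound 1 to compound 4 (0.19 log units; within the scatter) sets it level with the 2,4,5-trifluorophenyl ring, leaving the plain phenyl alone among these rings at the low end. Nothing shown here explains the jump.

As far as these compounds go, whether the rise belongs to the methyl itself or would follow any group at this place stays open. A chlorine atom or a methoxy group here would help separate the two.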